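The source may report more compounds than this note shows. Statements on the series, on what has been measured and on what is new or still open speak of the compounds shown alone.

Two compounds have been measured in a functional assay on PC-3 cells (Homo sapiens) for cytotoxicity; on this read-out higher numbers stand for weaker inhibition of growth and lower numbers for stronger inhibition of growth:

- compound 1, `CC(C)(C)OC(=O)N1c2ccccc2CC1C(=O)Nc1cccc(C(F)(F)F)c1`, gives 3340 nM
- compound 2, `Cc1ccc(S(=O)(=O)N2c3ccccc3CC2C(=O)Nc2ccc(C(F)(F)F)cc2)cc1`, gives 6680 nM

Compound 1 holds the lowest of the two numbers in this assay. Going by the values given here, its nearest neighbour is compound 2, and the gap between the two values lies within the scatter, so no order between them is claimed; the two differ at more than one place and no single step joins them.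

Compound 3, `CC(C)(C)OC(=O)N1c2ccccc2CC1C(=O)Nc1cc(C(F)(F)F)ccc1C(F)(F)F`, is not yet measured. It differs from compound 1 by trifluoromethyl in place of hydrogen on an aromatic carbon, ortho to a large group and para to a trifluoromethyl group. Among the compounds with values here, no measured pair in this set shows a change of this kind, so the size of the step cannot be read from the data. The expected step from compound 1 to compound 3 is a 1.0-fold lower number from compound 1 to compound 3 (0.01 log units; within the scatter), with no direction beyond the scatter expected. Compound 3 is estimated at 3300 nM, within a range of 1100 nM to 10000 nM.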

Compound 3, concentration for 50% growth inhibition: 838 nM
Compound 3: the middle estimate sits 3.9-fold (0.60 log units) above what was measured; measured number below the stated range.
By their numbers in this assay, from the lowest: compound 3; then compounds 1 and 2 (each within the scatter of the next).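

In this assay, going by these compounds alone, trifluoromethyl in place of hydrogen on an aromatic carbon, ortho to a large group and para to a trifluoromethyl group, gives a 4.0-fold lower number from compound 1 to compound 3 (0.60 log units; beyond the scatter) and so provides the first single-place step. This aromatic carbon can therefore carry the added group with a gain in growth inhibition, a result that rests on this one pair and sets no general pattern. Nothing available here accounts for the size of this step.

Still open, as far as these compounds go, is whether another group on this carbon, such as chlorine, methoxy or an amine, gives a comparable step. Also open, from the compounds shown here alone, is whether the added trifluoromethyl group gives this step without the existing trifluoromethyl group para to it, or on the core of compound 2.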